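Alkyl chain length on the ring amine of benzimidazole antihistamines

The source may hold more compounds than are shown below. What is called first, only, known or untested is meant among the compounds shown, and "the series" means these compounds.

Measured compounds:
Compound 1, `CCCN1CCCN(c2nc3ccccc3n2CCOCC)CC1`: 8.4 nM
Compound 2, `CCOCCn1c(N2CCN(C)CC2)nc2ccccc21`: 10 nM
Compound 3, `CCCCN1CCCN(c2nc3ccccc3n2CCOCC)CC1`: 8.4 nM

Of the compounds shown here, three have been tested in a functional assay on ileum for inhibition of histamine H1 receptor (Cavia porcellus); on this read-out higher numbers stand for weaker inhibition and lower numbers for stronger inhibition. Compound 1 and compound 3 share one core, while the difference between that core and the core of compound 2 is not broken down here. In this assay compound 1 gives 8.4 nM, compound 3 gives 8.4 nM and compound 2 gives 10 nM; all three values lie within the scatter of one another.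

Going by the values given here, the one step measured between them is methyl in place of hydrogen on a saturated chain carbon, three bonds along the chain from an amine nitrogen in a ring, and it produced no change at the digits printed from compound 1 to compound 3 (within the scatter).

Compound 4, `CCOCCn1c(N2CCN(CC)CC2)nc2ccccc21`, is not yet measured. It differs from compound 2 by methyl in place of hydrogen on a saturated chain carbon bound to an amine nitrogen in a ring. This is the same kind of change as that from compound 1 to compound 3, but the place differs: there the methyl entered three bonds along the chain from the amine nitrogen in the ring, here it enters on a saturated chain carbon bound to that nitrogen. Because no change at the digits printed from compound 1 to compound 3 (within the scatter) was flat, a similar step is expected here, a 1.1-fold lower number from compound 2 to compound 4 (0.05 log units; within the scatter). Compound 4 is therefore estimated at 9 nM, roughly between 4 nM and 22 nM.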

Compound 4, half-maximal inhibitory concentration: 18 nM
Compound 4: the middle estimate sits 2.0-fold (0.30 log units) below what was measured; low and high end bracket the measured number.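

In this assay, methyl in place of hydrogen on a saturated chain carbon bound to an amine nitrogen in a ring gave a 1.8-fold higher number from compound 2 to compound 4 (0.26 log units; within the scatter). Set beside the earlier step, the same kind of change reads alike on the two cores: the same change on two cores in this assay, no change at the digits printed (within the scatter) from compound 1 to compound 3 and a 1.8-fold higher number (0.26 log units; within the scatter) from compound 2 to compound 4, 1.8-fold (0.26 log units) apart, within the scatter of two such steps. This shows only that, in these two pairs, the change stayed within the scatter on either core; it does not show that the step carries over to other cores, and the methyl enters at a different place in each pair, so one pair per core cannot separate place from core.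

The compounds shown leave open whether a longer chain such as propyl or butyl on the core of compound 2, or a shorter one such as methyl or ethyl on the core of compound 1, would give numbers within the scatter of those already seen in this assay. They also leave open how a chain ending in an amine or a carboxylic acid would read there.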